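Notes on the step from compound 3 to compound 4

The source may hold more compounds than are shown below. What is called first, only, known or untested is meant among the compounds shown, and "the series" means these compounds.

Compound 1 `COc1ccc(-c2nn(-c3ccccc3)cc2C(=O)/C=C\Nc2ccc(Cl)cc2)cc1` gives 20900 nM in an ADME assay on HaCaT cells (Homo sapiens) for antiproliferative activity, read by MTT assay, with a stated time of 48 h; on this read-out higher numbers stand for weaker inhibition and lower numbers for stronger inhibition. Compound 2 `COc1ccc(N/C=C\C(=O)c2cn(-c3ccccc3)nc2-c2ccc(OC)cc2)cc1` reports only a limit of this assay, > 50000 nM. Compound 3 `COc1ccc(-c2nn(-c3ccccc3)cc2C(=O)/C=C\Nc2cc(OC)c(OC)c(OC)c2)cc1` likewise reports only a limit, > 50000 nM. Compound 3 therefore stands at the limit of > 50000 nM in this assay, at which 2 of the 3 values shown sit, and no number is known for it. Compound 4 `COc1cc(N/C=C\C(=O)c2cn(-c3ccccc3)nc2-c2cc(OC)c(OC)c(OC)c2)cc(OC)c1OC` differs from compound 3 by 3,4,5-trimethoxyphenyl in place of 4-methoxyphenyl on an aromatic carbon. For the measured compounds named here, no measured step touches this aromatic carbon. The steps that change the group on the amine nitrogen, an at least 2.3-fold higher number from compound 1 to compound 3 (0.37 log units; beyond the scatter) and a step that the two limits leave unreadable from compound 2 to compound 3, bear only loosely on it, and the exchange of chloro for methoxy gives an at least 2.3-fold higher number from compound 1 to compound 2 (0.37 log units; beyond the scatter). The estimated step is a step that the limit leaves unreadable from compound 3 to compound 4, so compound 4 is expected to remain at or near the limit. For compound 4 the estimated value is 70000 nM, with a range from 30000 nM to 200000 nM.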

Compound 4, half-maximal inhibitory concentration: 20900 nM
For compound 4 the middle estimate is 3.3-fold (0.52 log units) above the measured one; measured number outside the range, below it.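

For the compounds shown here, the aromatic carbon of the five-membered ring carried only 4-methoxyphenyl in the earlier compounds, so this exchange is new: in this assay, 3,4,5-trimethoxyphenyl in place of 4-methoxyphenyl gives an at least 2.3-fold lower number from compound 3 to compound 4 (0.37 log units; beyond the scatter). With 3,4,5-trimethoxyphenyl already on the amine nitrogen, this position still moves the read-out off the limit. The true size of the step stays a lower bound, since compound 3 holds only a limit: the limit of > 50000 nM in this assay, at which 2 of the 4 values shown sit.

Open, as far as these compounds go, is whether the same exchange holds with 4-chlorophenyl on the amine nitrogen. Also open, from the compounds shown here alone, is how a carboxylic acid or an amine on this phenyl ring would read.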